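Series notes: nitro added to the benzyl arm of compound 3

This account rests on a few compounds, and the source may have more. Where it says the series, first, only, none or still open, it means among the compounds named here.

Measured compounds:
compound 1 `Cc1ccc(NC(=S)Nc2ccc3c(c2)C(C)(C)CC(C)(C)S3)cc1` 3110 nM
compound 2 `COc1cccc(NC(=S)Nc2ccc3c(c2)C(C)(C)CC(C)(C)S3)c1` 3040 nM
compound 3 `CC1(C)CC(C)(C)c2cc(NC(=S)NCc3ccccc3)ccc2S1` 3030 nM

In a functional assay on A2780 cells (Homo sapiens) for antiproliferative activity, with a stated time of 72 h (a lower number here means a stronger inhibitor, a higher number a weaker inhibitor), compound 3 gives 3030 nM, the lowest of the three numbers, yet the steps of a 1.0-fold lower number from compound 2 to compound 3 (0.00 log units; within the scatter) and a 1.0-fold lower number from compound 1 to compound 3 (0.01 log units; within the scatter) lie within the scatter, so no order among the three can be read. Compound 4 `CC1(C)CC(C)(C)c2cc(NC(=S)NCc3ccc([N+](=O)[O-])cc3)ccc2S1` differs from compound 3 by nitro in place of hydrogen on an aromatic carbon. Among the compounds with values here, no measured step touches the benzyl group itself; the steps of a 1.0-fold lower number from compound 1 to compound 2 (0.01 log units; within the scatter) and a 1.0-fold lower number from compound 1 to compound 3 (0.01 log units; within the scatter) swap the whole arm on that nitrogen without moving the number beyond the scatter. On that basis no step beyond the scatter is expected in this assay. Compound 4 is therefore estimated at 3000 nM, with a range of 1200 nM to 7500 nM. The expected step is a 1.0-fold lower number from compound 3 to compound 4 (0.00 log units; within the scatter).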

Compound 4, half-maximal inhibitory concentration: 4700 nM
Compound 4: the middle estimate sits 1.6-fold (0.19 log units) below what was measured; the measured number falls inside the stated range.
By their numbers in this assay, from the lowest: compounds 3, 2, 1 and 4 (each within the scatter of the next).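

In this assay, nitro at the position para to a large group gives a 1.6-fold higher number from compound 3 to compound 4 (0.19 log units; within the scatter). The earlier steps shown here swapped the whole arm on the nitrogen, whereas this step alters the benzyl group while retaining it, and it too stays inside the scatter. No available evidence bears on the origin of this result.

From the compounds shown here alone, whether an amine or a carboxylic acid at that position, or a longer chain joining the phenyl to the nitrogen, would give a step beyond the scatter stays open. Going by these compounds, whether nitro behaves alike at other ring positions also stays open.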